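The source may hold more compounds than are shown below. What is called first, only, known or untested is meant among the compounds shown, and "the series" means these compounds.

Measured so far:
- compound 1 `CC(C)(C)S(=O)(=O)Nc1ccc(-c2c(C(N)=O)c3cc(F)c(OC(F)F)cc3n2-c2ccccc2)cc1`: 7670 ng.h/mL in an ADME assay on the whole organism (plasma, strain Sprague-Dawley) for pharmacokinetics, with Rattus norvegicus as the target, with stated times of 6 h and 30 min, at a dose of 10 mg/kg by the oral route; on this read-out lower numbers stand for lower exposure and higher numbers for higher exposure at the dose given
- compound 2 `Cc1cc2c(cc1F)c(C(N)=O)c(-c1ccc(NS(=O)(=O)C(C)(C)C)cc1)n2C1CCCCC1`: in this assay compound 2 gives 333 ng.h/mL
- compound 3 `Cc1cc2c(cc1F)c(C(N)=O)c(-c1ccc(NS(=O)(=O)C(C)(C)C)cc1)n2-c1ccccc1`: in this assay compound 3 gives 7140 ng.h/mL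

Compounds 1 and 3 share a core and differ in one place, (difluoromethoxy in place of methyl on an aromatic carbon), and the step is a 1.1-fold higher number from compound 3 to compound 1 (0.03 log units; within the scatter). Compounds 2 and 3 differ in their cores, (cyclohexyl in place of phenyl on an aromatic nitrogen), and here the step is a 21-fold higher number from compound 2 to compound 3 (1.33 log units; beyond the scatter). Compound 2 stands lowest of the three in this assay, with its steps to both others beyond the scatter.

Compound 4 `CC(C)(C)S(=O)(=O)Nc1ccc(-c2c(C(N)=O)c3cc(F)c(OC(F)F)cc3n2C2CCCCC2)cc1` is not yet measured. It carries the same change relative to compound 2, (difluoromethoxy in place of methyl on an aromatic carbon), as compound 1 carries relative to compound 3; the surroundings of the place are described in the same words in both cases, so this is the same change made on the second core, and among the compounds shown it occurs twice in all.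

For compound 4 the expected step in this assay is a 1.1-fold higher number from compound 2 to compound 4 (0.03 log units; within the scatter), beside the measured 1.1-fold higher number from compound 3 to compound 1 (0.03 log units; within the scatter), resting on that single precedent on the other core. Compound 4 is accordingly estimated at 360 ng.h/mL, with a range from 150 ng.h/mL to 900 ng.h/mL.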

Compound 4, area under the concentration-time curve: 447 ng.h/mL
The estimate for compound 4 lay 1.2-fold (0.09 log units) below the measured number; the range from low to high includes it.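

On the core of compound 2, difluoromethoxy in place of methyl on an aromatic carbon gives a step within the scatter in this assay, a 1.3-fold higher number from compound 2 to compound 4 (0.13 log units; within the scatter), and this agrees with the earlier step on the other core: the same change on two cores in this assay, a 1.1-fold higher number (0.03 log units; within the scatter) from compound 3 to compound 1 and a 1.3-fold higher number (0.13 log units; within the scatter) from compound 2 to compound 4, 1.2-fold (0.10 log units) apart, within the scatter of two such steps. Cyclohexyl in place of phenyl on an aromatic nitrogen gives a large step, a 17-fold lower number from compound 1 to compound 4 (1.23 log units; beyond the scatter), and its size also carries from one core to the other: the same change on two cores in this assay, a 21-fold higher number (1.33 log units; beyond the scatter) from compound 2 to compound 3 and a 17-fold higher number (1.23 log units; beyond the scatter) from compound 4 to compound 1, 1.2-fold (0.10 log units) apart, within the scatter of two such steps. For the compounds shown here, this shows that, in these four compounds, the two changes read the same on either background, but each rests on only one pair per background, and the data give no reason for the large step or show that this agreement extends to other compounds.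

The compounds shown leave open whether the same holds for another group on the aromatic carbon, such as methoxy or chloro. They also leave open what an amine or a longer chain would give on the aromatic nitrogen in place of phenyl or cyclohexyl.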